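Compound 3 after a flat fluoro to methoxy step

A few compounds are considered here, and "the series" means these few. Any claim that something is new, unique, unknown or untested is made for them only; others in the source may bear on it.

Compound 1 `Cc1ccc(CS/C(=C/c2ccccc2F)C(=O)c2ccc(Cl)cc2)cc1` – 10000 nM
Compound 2 `COc1ccccc1/C=C(/SCc1ccc(C)cc1)C(=O)c1ccc(Cl)cc1` – 10000 nM

Level with compound 1, compound 2 gives 10000 nM in a functional assay on DU-145 cells (Homo sapiens) for inhibition, read by trypan blue exclusion, with a stated time of 96 h; a lower number here means a stronger inhibitor of growth, a higher number a weaker inhibitor of growth. Compound 3 `Cc1ccc(CS/C(=C/c2c[nH]c3ccc(Cl)cc23)C(=O)c2ccc(Cl)cc2)cc1` differs from it by 5-chloro-1H-indol-3-yl in place of 2-methoxyphenyl on a double-bonded chain carbon bound to a double-bonded chain carbon. For the measured compounds named here, the only measured step, no change at the digits printed from compound 1 to compound 2 (within the scatter), concerns a different change and offers weak guidance. It shows no movement, so no step beyond the scatter is expected in this assay, although the data cannot exclude one. The estimated step is a 1.7-fold lower number from compound 2 to compound 3 (0.22 log units; within the scatter). Compound 3 is expected at 6000 nM, with an estimated range of 1500 nM to 15000 nM.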

Compound 3, concentration for 50% growth inhibition: 1000 nM
For compound 3 the middle estimate is 6.0-fold (0.78 log units) above the measured one; measured number outside the range, below it.
By their numbers in this assay, from the lowest: compound 3; then compounds 1 and 2 (each within the scatter of the next).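

In this assay, this place on a double-bonded chain carbon bound to a double-bonded chain carbon turns out to be able to move the number. Exchanging one substituted phenyl for another had left it flat (no change at the digits printed from compound 1 to compound 2 (within the scatter)), whereas 5-chloro-1H-indol-3-yl gives a clear shift, both in place of 2-methoxyphenyl (a 10-fold lower number from compound 2 to compound 3 (1.00 log units; beyond the scatter)) and in place of 2-fluorophenyl (a 10-fold lower number from compound 1 to compound 3 (1.00 log units; beyond the scatter)). No measurement at hand accounts for this shift. As far as these compounds go, whether the 1H-indol-3-yl group without its chlorine, or with a methoxy in the chlorine's stead, would hold this level stays open, as does whether the shift survives changes elsewhere on the shared core.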